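This account rests on a few compounds, and the source may have more. Where it says the series, first, only, none or still open, it means among the compounds named here.

Measured so far:
compound 1 `Cc1cc(C)cc(NC(=O)Nc2cc(C(C)(C)C)nn2-c2ccccc2)c1`: -0.3 degrees C
compound 2 `Cc1ccc(S(=O)(=O)NC(=O)Nc2cc(C(C)(C)C)nn2-c2ccccc2)cc1`: -0.9 degrees C

In an assay on isolated protein for inhibition of serine/threonine-protein kinase 10 (Homo sapiens), read by thermal shift assay, tested at 10 uM (a higher number here means that the compound stabilises the target more against heat, a lower number that the compound stabilises the target less), compound 1 gives -0.3 degrees C, and compound 2 gives -0.9 degrees C; the two values lie within the scatter of each other, so neither stands apart, and both indicate little stabilisation of the target. Compound 3 `CC(C)(C)c1cc(NC(=O)Nc2cc(F)cc(F)c2)n(-c2ccccc2)n1` differs from compound 1 in one place: 3,5-difluorophenyl in place of 3,5-dimethylphenyl on an amide-type nitrogen. Going by the values given here, no measured pair shows such a change, so there is nothing to set its size against. Given that compound 1 gives -0.3 degrees C in this assay, the expected step of a number 0.20 degrees C lower from compound 1 to compound 3 (within the scatter) is none beyond the scatter. Compound 3 is therefore estimated at -0.5 degrees C, in a range from -1.8 degrees C to 0.8 degrees C.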

Compound 3, shift of the target's melting temperature: 2.5 degrees C
For compound 3 the middle estimate is 3.0 degrees C below the measured one; measured number outside the range, above it.
By their numbers in this assay, from the lowest: compounds 2 and 1 (each within the scatter of the next); then compound 3.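

In this assay the read-out moves a number 2.8 degrees C higher from compound 1 to compound 3 (beyond the scatter) when 3,5-difluorophenyl replaces 3,5-dimethylphenyl on the amide-type nitrogen, so this position responds to the change. The two groups have the same count of heavy atoms and the same ring, which shows that exchanging the two methyl groups for two fluorines is enough to lift the number beyond the scatter. Nothing available explains this rise. From the compounds shown here alone, it remains open whether 3-fluorophenyl or 3,5-dichlorophenyl on that nitrogen would give a similar number, and whether 3,5-bis(trifluoromethyl)phenyl would go further.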